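Cyclopropylmethoxy in Place of Fluoro on a Shared Core

The source may hold more compounds than are shown below. What is called first, only, known or untested is meant among the compounds shown, and "the series" means these compounds.

Three measured compounds share one core. In a functional assay on PC-3 cells (Homo sapiens) for antiproliferative activity, read by MTT assay, with a stated time of 12 h (a lower number here means a stronger inhibitor, a higher number a weaker inhibitor), compound 1 `COc1ccc2c(=O)cc(/C=C/c3ccc(OC(F)(F)F)cc3)oc2c1` gives only a limit, > 40000 nM. Compound 2 `COc1cc(OC)c2c(=O)cc(/C=C/c3ccc(F)cc3)oc2c1` likewise gives only a limit in this assay, > 40000 nM. Compound 3 `COc1cc(OC)c2c(=O)cc(/C=C/c3ccncc3)oc2c1` also returns a limit, > 40000 nM. The step that the two limits leave unreadable from compound 2 to compound 3 cannot be read, since every value sits at the limit of > 40000 nM in this assay, at which 3 of the 3 values shown sit. Compound 4 `COc1cc(OC)c2c(=O)cc(/C=C/c3ccc(OCC4CC4)cc3)oc2c1` differs from compound 2 by cyclopropylmethoxy in place of fluoro on an aromatic carbon. Within the data shown here, no measured step in this assay bears readably on this change, so neither direction nor size can be drawn from the data; compound 2 itself stands only at the limit, without a number. Compound 4 is therefore expected to remain near that limit, with a step of an at least 1.3-fold lower number from compound 2 to compound 4 (0.12 log units; that floor lies within the scatter) estimated. The estimate for compound 4 is 30000 nM, within 8000 nM to 80000 nM.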

Compound 4, half-maximal inhibitory concentration: > 40000 nM
Compound 4: a limit, no number (the forecaster's own chance of this, stated with the estimate: 60%); middle value at least 1.3-fold (0.12 log units) away from the limit.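

In this assay, among these compounds, compound 4 gives > 40000 nM as a limit and not a number, and compound 2 also stands at a limit, so no step between the two can be read. From the compounds shown here alone, how any change on the shared core shifts the read-out in this assay remains open.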